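This account rests on a few compounds, and the source may have more. Where it says the series, first, only, none or still open, it means among the compounds named here.

Measured so far in a functional assay on A549 cells (Homo sapiens) for inhibition, read by sulforhodamine B assay, with a stated time of 48 h, tested at 0.1 uM; on this read-out higher numbers stand for a weaker effect at the one concentration tested and lower numbers for a stronger effect:

compound 1, `O=C(Nc1cccc(-n2cc(-c3ccncc3)c(-c3cc(O)cc(Cl)c3)n2)c1)Nc1ccc(Cl)c(C(F)(F)F)c1`: 100%
compound 2, `O=C(Nc1cccc(-n2cc(-c3ccncc3)c(-c3cc(O)cc(Cl)c3)n2)c1)Nc1ccc(Cl)c(Cl)c1`: 99%
compound 3, `COc1cc(Cl)cc(-c2nn(-c3cccc(NC(=O)Nc4ccc(Cl)c(C(F)(F)F)c4)c3)cc2-c2ccncc2)c1`: 98%

All three numbers sit close to the top of the read-out, so none of these compounds shows more than a marginal effect at the single concentration tested. Compound 3 holds the lowest of the three values, yet its gaps to the others are small: its nearest neighbour is compound 2 and its furthest is compound 1, both within the scatter, so no ordering among the three is supported.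

Compound 4 is `COc1cc(Cl)cc(-c2nn(-c3cccc(NC(=O)Nc4ccc(Cl)c(Cl)c4)c3)cc2-c2ccncc2)c1`. It differs from compound 3 in one place: chloro in place of trifluoromethyl on an aromatic carbon.

The same exchange has been made once before in this set, on the pair that carries hydrogen instead of methyl on the ring oxygen: a number 1 percentage points lower from compound 1 to compound 2 (within the scatter). That step lies within the scatter. The methyl-for-hydrogen exchange that separates compound 1 from compound 3 is likewise flat, a number 2 percentage points lower from compound 1 to compound 3 (within the scatter), so nothing suggests the two changes interact. The expectation for this assay is therefore no step beyond the scatter, no change at the digits printed from compound 3 to compound 4 (within the scatter). Compound 4 is estimated at 98%, with a range from 92% to 104%.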

Compound 4, a percentage reported as activity, at one concentration (the size of the read-out at that concentration, not a potency): 97%
Beside the measured number, compound 4's estimate is 1 percentage points above it; the measured number falls inside the stated range.
By their numbers in this assay, from the lowest: compounds 4, 3, 2 and 1 (each within the scatter of the next).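

In this assay, chloro in place of trifluoromethyl on the aromatic carbon ortho to a chloro group now also gives a number 1 percentage points lower from compound 3 to compound 4 (within the scatter), so this exchange has a second reading, on the methyl ether: the same change on two cores in this assay, a number 1 percentage points lower (within the scatter) from compound 1 to compound 2 and a number 1 percentage points lower (within the scatter) from compound 3 to compound 4, 0 percentage points apart, within the scatter of two such steps Methyl in place of hydrogen on the ring oxygen, until now read only with the 4-chloro-3-(trifluoromethyl)phenyl group, gives a number 2 percentage points lower from compound 2 to compound 4 (within the scatter) with the 3,4-dichlorophenyl group: the same change on two cores in this assay, a number 2 percentage points lower (within the scatter) from compound 1 to compound 3 and a number 2 percentage points lower (within the scatter) from compound 2 to compound 4, 0 percentage points apart, within the scatter of two such steps Across these four compounds, each change therefore reads the same whichever form the other site takes, though all four values lie close to the top of the read-out, where the compounds show little effect.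

As far as these compounds go, whether a different kind of group on this aromatic carbon, such as an amine or a carboxylic acid, or a longer chain on the ring oxygen, would give a step beyond the scatter remains open. From the compounds shown here alone, with a single concentration and no potency values, it also remains open whether these two changes would stay equally flat under conditions where the compounds show a clear effect.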